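The source may hold more compounds than are shown below. What is called first, only, known or untested is meant among the compounds shown, and "the series" means these compounds.

Working notes on the series built on the shared core of compound 1 `C=CCOc1cc(OC)c(C(=O)/C=C/c2ccc(F)cc2)c(OCC=C)c1`. In an ADME assay on Vero cells (Chlorocebus sabaeus) for cytotoxicity, read by MTT assay (a higher number here means a weaker inhibitor, a lower number a stronger inhibitor), compound 1 gives 13600 nM, compound 2 `C=CCOc1cc(OC)c(C(=O)/C=C/c2ccc(O)cc2)c(OCC=C)c1` gives 76400 nM and compound 3 `C=CCOc1cc(OC)c(C(=O)/C=C/c2ccccc2F)c(OCC=C)c1` gives 16300 nM. Compound 3 therefore stands with compound 1, as shown by a 1.2-fold higher number from compound 1 to compound 3 (0.08 log units; within the scatter), and apart from compound 2, as shown by a 4.7-fold lower number from compound 2 to compound 3 (0.67 log units; beyond the scatter).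

The next change leads to compound 4 `C=CCOc1cc(OC)c(C(=O)/C=C/c2ccncc2)c(OCC=C)c1`: pyridin-4-yl in place of 2-fluorophenyl on a double-bonded chain carbon bound to a double-bonded chain carbon. In words, this is pyridin-4-yl in place of 2-fluorophenyl on a double-bonded chain carbon bound to a double-bonded chain carbon.

Among the measured compounds shown here, no measured compound carries pyridin-4-yl, so the evidence is indirect. Replacing 4-fluorophenyl with 2-fluorophenyl gave a 1.2-fold higher number from compound 1 to compound 3 (0.08 log units; within the scatter), which offers no sign of movement. Hydroxy in place of fluoro gave a 5.6-fold higher number from compound 1 to compound 2 (0.75 log units; beyond the scatter), the one change from compound 1 that went beyond the scatter. Compound 2 has a hydrogen-bond acceptor on this ring where the fluorinated compounds are counted differently, so it is only a loose guide, and the expectation leans towards it with caution.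

In this assay, a modest move to a higher number is expected, estimated as a 2.1-fold higher number from compound 3 to compound 4 (0.33 log units; beyond the scatter). For compound 4 the estimated value is 35000 nM, with an expected range from 14000 nM to 85000 nM.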

Compound 4, half-maximal inhibitory concentration: 2800 nM
The estimate for compound 4 lay 13-fold (1.10 log units) above the measured number, outside the stated range (below it).
By their numbers in this assay, from the lowest: compound 4; then compounds 1 and 3 (each within the scatter of the next); then compound 2.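

In this assay, pyridin-4-yl on a double-bonded chain carbon bound to a double-bonded chain carbon gives the lowest number of the four compounds, with a 5.8-fold lower number from compound 3 to compound 4 (0.77 log units; beyond the scatter), a 4.9-fold lower number from compound 1 to compound 4 (0.69 log units; beyond the scatter) and a 27-fold lower number from compound 2 to compound 4 (1.44 log units; beyond the scatter). Among the compounds shown here, this is the first change at this position to give a lower number than compound 1, whereas the earlier changes from compound 1 gave a 1.2-fold higher number from compound 1 to compound 3 (0.08 log units; within the scatter) and a 5.6-fold higher number from compound 1 to compound 2 (0.75 log units; beyond the scatter), so the position can move the number in both directions, and compound 4 and compound 2 now mark the two ends of the series. Nothing available here bears on why replacing the carbon-only ring with a ring holding one nitrogen lowers the number.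

The compounds shown leave open whether the lower number is particular to pyridin-4-yl or would also appear with pyridin-3-yl or pyridin-2-yl, and whether a pyrimidinyl group, with a second ring nitrogen, would lower it further. They also leave open how an amine or a carboxylic acid on the ring at this position would compare with compound 4.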